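A carbamoyl swap at the limit of the assay

A few compounds are considered here, and "the series" means these few. Any claim that something is new, unique, unknown or untested is made for them only; others in the source may bear on it.

Compound 1 `CCNC(=O)c1nc(-c2ccccc2)[nH]c1C(=O)O` gives "not determined" (no result reported)
Compound 2 `O=C(O)c1[nH]c(-c2ccccc2)nc1C(=O)N1CCOCC1` gives > 200000 nM
Compound 3 `CN(Cc1ccccc1)C(=O)c1nc(-c2ccccc2)[nH]c1C(=O)O` gives > 200000 nM

In a functional assay on PC-3 cells (Homo sapiens) for inhibition (on this read-out lower numbers stand for stronger inhibition of growth and higher numbers for weaker inhibition of growth), compound 3 stands at a limit (> 200000 nM), which is not an exact number. Compound 2 also stands at a limit (> 200000 nM). Compound 4 `CN(CC(N)=O)C(=O)c1nc(-c2ccccc2)[nH]c1C(=O)O` differs from compound 3 by having carbamoyl in place of phenyl on a saturated chain carbon bound to an amide-type nitrogen, that is, benzyl to carbamoylmethyl (carbamoyl in place of phenyl on a saturated chain carbon bound to an amide-type nitrogen). Going by the values given here, no measured step gives the size of this change. With compound 3 known only as a limit (> 200000 nM), no step beyond the scatter is expected in this assay. The estimated step is small (a number no higher from compound 3 to compound 4 (the limit leaves the size open)). Compound 4 is estimated at (200000 nM), with an expected range (80000 nM to 400000 nM).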

Compound 4, concentration for 50% growth inhibition: > 200000 nM
Compound 4: only a limit was reported (the forecaster's own chance of this, stated with the estimate: 85%); the middle value lies on the limit itself.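

No step can be read from compound 3 to compound 4 or from compound 2 to compound 4, since all three give only a limit: the limit of > 200000 nM in this assay, at which 3 of the 4 values shown sit. The compounds shown leave open how far apart their true values lie, and whether any amide group on the shared core gives measurable inhibition of growth.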